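Furan-2-yl in Place of 4-Fluorophenyl on a Shared Core

A few compounds are considered here, and "the series" means these few. Any claim that something is new, unique, unknown or untested is made for them only; others in the source may bear on it.

Compound 1 `CC1(C)CC12NC(=O)N(NC(=O)c1ccc(Cl)cc1)C2=O` and compound 2 `CC1(C)CC12NC(=O)N(NC(=O)c1ccc(F)cc1)C2=O` share one core and differ only by fluoro in place of chloro on an aromatic carbon. In a functional assay on the whole organism (Hindlimb) for inhibition, with Mus musculus as the target, with a stated time of 4 h (a lower number here means that less compound is needed, a higher number that more compound is needed for the effect), compound 1 gives 300 mg/kg, and compound 2 gives 300 mg/kg; the step of no change at the digits printed from compound 1 to compound 2 (within the scatter). Compound 2 thus stands level with compound 1. Compound 3 `CC1(C)CC12NC(=O)N(NC(=O)c1ccco1)C2=O` carries furan-2-yl in place of 4-fluorophenyl on a carbonyl carbon. For the measured compounds named here, no measured step touches this group, and the only known step lies within the scatter, so no change beyond the scatter is expected for compound 3, the expected step being no change at the digits printed from compound 2 to compound 3 (within the scatter). Compound 3 is estimated at 300 mg/kg, between 100 mg/kg and 600 mg/kg.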

Compound 3, minimum effective dose: 300 mg/kg
For compound 3 middle estimate and measured number coincide at the digits printed; measured number inside the range.
By their numbers in this assay, from the lowest: compounds 1, 2 and 3 (each within the scatter of the next).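

In this assay, the change reaches beyond the halogen swap to the aromatic ring on the carbonyl carbon itself: furan-2-yl in place of 4-fluorophenyl gives no change at the digits printed from compound 2 to compound 3 (within the scatter), and furan-2-yl in place of 4-chlorophenyl gives no change at the digits printed from compound 1 to compound 3 (within the scatter). A five-membered aromatic ring with one hetero atom thus reads the same here as a six-membered aromatic ring of carbon only. No available evidence bears on this result. The compounds shown leave open whether a non-aromatic group on that carbonyl carbon, such as a longer alkyl chain or an amine, would shift the minimum effective dose.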